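The source may report more compounds than this note shows. Statements on the series, on what has been measured and on what is new or still open speak of the compounds shown alone.

Measured compounds:
- compound 1 `CC(C)c1onc(-c2c(Cl)cccc2Cl)c1COc1ccc(-c2ccc3nc(C(=O)O)cc(O)c3c2)cc1` — 51 nM
- compound 2 `CCOc1cc(C(=O)O)nc2ccc(-c3ccc(OCc4c(-c5c(Cl)cccc5Cl)noc4C(C)C)cc3)cc12` — 52 nM
- compound 3 `CC(C)Oc1cc(C(=O)O)nc2ccc(-c3ccc(OCc4c(-c5c(Cl)cccc5Cl)noc4C(C)C)cc3)cc12` — 40 nM

All three are characterised in a functional assay for agonist activity at Bile acid receptor (Homo sapiens), read by FRET; a lower number here means that less compound is needed, a higher number that more compound is needed for the effect. Compound 3 sits at the lower end of the three numbers, but the steps of a 1.3-fold lower number from compound 1 to compound 3 (0.11 log units; within the scatter) and a 1.3-fold lower number from compound 2 to compound 3 (0.11 log units; within the scatter) are both within the scatter, so the three compounds are not separated from one another on this read-out. The step of a 1.0-fold higher number from compound 1 to compound 2 (0.01 log units; within the scatter) is likewise within the scatter.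

Compound 4 `CCCOc1cc(C(=O)O)nc2ccc(-c3ccc(OCc4c(-c5c(Cl)cccc5Cl)noc4C(C)C)cc3)cc12` is the next member of the series. It differs from compound 3 as follows: propyl in place of isopropyl on an oxygen on an aromatic ring. Within the data shown here, the steps that bear on this position all concern the same oxygen on the aromatic ring: hydrogen to ethyl, hydrogen to isopropyl, and ethyl to isopropyl, none of which moved this assay beyond the scatter. The change from isopropyl to propyl keeps the same count of carbons at that oxygen and only rearranges them, so no step beyond the scatter is expected in this assay, in either direction; the expected step is a 1.1-fold higher number from compound 3 to compound 4 (0.05 log units; within the scatter). For compound 4 the estimate in this assay is 45 nM, with a range from 20 nM to 100 nM.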

Compound 4, half-maximal effective concentration: 59 nM
The estimate for compound 4 lay 1.3-fold (0.12 log units) below the measured number; low and high end bracket the measured number.
By their numbers in this assay, from the lowest: compounds 3, 1, 2 and 4 (each within the scatter of the next).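

In this assay, moving the same three carbons on the oxygen from isopropyl to propyl gives a 1.5-fold higher number from compound 3 to compound 4 (0.17 log units; within the scatter) and stays within the scatter, so the branched and straight forms are not separated on this read-out. Propyl is also not separated from the shorter ethyl (a 1.1-fold higher number from compound 2 to compound 4 (0.05 log units; within the scatter)) or from hydrogen on the same oxygen (a 1.2-fold higher number from compound 1 to compound 4 (0.06 log units; within the scatter)), which extends the flat picture at this position to four groups: hydrogen, ethyl, isopropyl and propyl, with compounds 1, 2, 3 and 4 showing no step beyond the scatter and none going against this. No independent measurement bears on these steps, so the data offer no account of this flat picture.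

Still open, from the compounds shown here alone, is whether a longer chain such as butyl or hexyl on this oxygen would give a step beyond the scatter, or whether the flat picture ends only with a larger group such as benzyl. Equally open, going by these compounds, is how an amine or a carboxylic acid at the end of a chain on this oxygen would read in this assay and whether either would separate from the four groups seen so far.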